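Ethyl-to-methyl swap in a set of inactive succinimides

The source may hold more compounds than are shown below. What is called first, only, known or untested is meant among the compounds shown, and "the series" means these compounds.

Of the compounds shown here, three have been tested in a functional assay on the whole organism (strain Swiss) with Mus musculus as the target, in the maximal electroshock model, with a stated time of 1 h, at a dose of 100 mg/kg by the intraperitoneal route; a lower number here means a weaker effect, a higher number a stronger effect of the compound at the dose given. Compound 1 `CC(C(=O)N1CCN(c2ccccc2F)CC1)N1C(=O)CCC1=O` gives 0%, compound 2 `CCC(C(=O)N1CCN(c2ccccc2F)CC1)N1C(=O)CCC1=O` gives 0%, and compound 3 `CCC(C(=O)N1CCN(c2cccc(C(F)(F)F)c2)CC1)N1C(=O)CCC1=O` gives 0% in this assay. Compound 2 and compound 1 differ in one place: hydrogen in place of methyl on a saturated chain carbon, two bonds along the chain from an amide-type nitrogen in a ring and a carbonyl carbon. This change gives no change at the digits printed from compound 2 to compound 1 (within the scatter). The difference between the core of compound 2 and the core of compound 3 is not broken down here.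

Compound 4 `CC(C(=O)N1CCN(c2cccc(C(F)(F)F)c2)CC1)N1C(=O)CCC1=O` has not yet been measured. It differs from compound 3 in the same way: hydrogen in place of methyl on a saturated chain carbon, two bonds along the chain from an amide-type nitrogen in a ring and a carbonyl carbon. Both changes sit at the same place, so this is the same change seen once already.

Because no change at the digits printed from compound 2 to compound 1 (within the scatter) shows the earlier step left the read-out where it was, the step from compound 3 to compound 4 is expected to be of the same size, that is no change at the digits printed from compound 3 to compound 4 (within the scatter) in this assay. Compound 4 is therefore estimated to give 0% in this assay, with a range expected from 0% to 10%. This rests on a single earlier step and three measured compounds only.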

Compound 4, a percentage reported as activity, at one dose (the size of the read-out at that dose, not a potency): 50%
The estimate for compound 4 lay 50 percentage points below the measured number; measured number above the stated range.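

In this assay, shortening the ethyl chain to methyl gives a number 50 percentage points higher from compound 3 to compound 4 (beyond the scatter). The earlier step on the other core looks quite different, so this change cannot be carried from one core to the other and be expected to keep its size: the same change on two cores in this assay, no change at the digits printed (within the scatter) from compound 2 to compound 1 and a number 50 percentage points higher (beyond the scatter) from compound 3 to compound 4, 50 percentage points apart, beyond the scatter of two such steps

This shows that, for these two pairs, the outcome of the swap depends on the core it is made on, but it does not show which feature of the two cores matters, or how the swap would behave on any further core. Each reading also comes from a single dose, so it is not a measure of potency.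

The compounds shown leave open whether a longer chain such as propyl, in place of the methyl of compound 4, would keep the read-out. They also leave open whether a chlorine or a nitrile, in place of the trifluoromethyl group of compound 4, would do the same.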